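Swapping a phenoxypropyl ether for a phenyl carbamate

This account rests on a few compounds, and the source may have more. Where it says the series, first, only, none or still open, it means among the compounds named here.

Compound 2 `COc1ccc(OCCCOc2cc(=O)n(CCCO)c3c2CC(C/C=C(\C)CCC=C(C)C)C(C)(C)C3)cc1` gives 20% in a functional assay on PANC-1 cells (Homo sapiens) for inhibition, read by MTT assay, with a stated time of 24 h, tested at 10 uM; on this read-out higher numbers stand for more inhibition at the one concentration tested (going by the name of the read-out) and lower numbers for less inhibition. Compound 1 `CC(C)=CCC/C(C)=C/COc1cc(=O)n(CCCO)c2c1CC(C/C=C(\C)CCC=C(C)C)C(C)(C)C2` gives 15.8% in this assay. Compound 2 thus shows the larger of the two numbers, but a number 4.2 percentage points higher from compound 1 to compound 2 (within the scatter), so the two are not separated. Compound 3 `COc1ccc(NC(=O)Oc2cc(=O)n(CCCO)c3c2CC(C/C=C(\C)CCC=C(C)C)C(C)(C)C3)cc1` remains to be measured; it differs from compound 2 by (4-methoxyphenyl)carbamoyl in place of 3-(4-methoxyphenoxy)propyl on an oxygen on an aromatic ring. For the measured compounds named here, the single measured step altered a different region and stayed within the scatter, and no step involving a carbamate exists to draw on, so no change beyond the scatter is expected. Compound 3 is therefore estimated to give 20%, between 8% and 35%. The expected step is no change at the digits printed from compound 2 to compound 3 (within the scatter).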

Compound 3, a percentage reported as inhibition, at one concentration (the size of the read-out at that concentration, not a potency): 64.1%
The estimate for compound 3 lay 44.1 percentage points below the measured number; the whole stated range lies below it.
By their numbers in this assay, from the lowest: compounds 1 and 2 (each within the scatter of the next); then compound 3.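

In this assay the group on the oxygen on an aromatic ring clearly matters, which the earlier step, made elsewhere and within the scatter, could not show. Placing (4-methoxyphenyl)carbamoyl there gives a number 44.1 percentage points higher from compound 2 to compound 3 (beyond the scatter) when it replaces 3-(4-methoxyphenoxy)propyl and a number 48.3 percentage points higher from compound 1 to compound 3 (beyond the scatter) when it replaces 3,7-dimethylocta-2,6-dien-1-yl, so two different ethers both fall well short of this carbamate. No measurement offered here explains the rise. Still open, as far as these compounds go, is whether the gain belongs to the carbamoyl link, the amide hydrogen or the 4-methoxyphenyl ring. A carbamoyl with a methyl group on its nitrogen, or a plain benzoyl ester, would help separate these.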